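The compounds below may be only part of what the source reports. "The series", "measured", "known", "first", "only" and "open" are said of these compounds alone.

Measured compounds in an in vitro functional assay on SH-EP1 cells for agonist activity at Neuronal acetylcholine receptor; alpha4/beta2 (Homo sapiens), read by FLIPR and calcium flux; a higher number here means that more compound is needed for the effect, a lower number that less compound is needed:
Compound 1, `Fc1ccc(C2=CC3CNCC(C2)C3)cn1`: compound 1 gives 85 nM.
Compound 2, `CN1CC2C=C(c3ccc(F)nc3)CC(C2)C1`: compound 2 reaches only a limit of the assay, > 10000 nM.
Compound 3, `CC(C)Oc1cncc(C2=CC3CNCC(C2)C3)c1`: compound 3 gives 562 nM.

Compound 3 shows a higher number than compound 1; the difference between the core of compound 1 and the core of compound 3 is not broken down here.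

Compound 4, `CC(C)Oc1cncc(C2=CC3CC(C2)CN(C)C3)c1`, is not yet measured. It differs from compound 3 by methyl in place of hydrogen on an amine nitrogen in a ring. The same change is made from compound 1 to compound 2, (methyl in place of hydrogen on an amine nitrogen in a ring), and there the step was an at least 110-fold higher number from compound 1 to compound 2 (2.07 log units; beyond the scatter), with compound 2 sitting at the limit of > 10000 nM in this assay, at which 1 of the 3 values shown sits.

The step from compound 3 to compound 4 is expected to be of similar size, a 71-fold higher number from compound 3 to compound 4 (1.85 log units; beyond the scatter), resting on the measured step of an at least 110-fold higher number from compound 1 to compound 2 (2.07 log units; beyond the scatter). Compound 4 is therefore estimated at 40000 nM, most likely reported only as a limit.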

Compound 4, half-maximal effective concentration: > 10000 nM
Compound 4 was reported as a limit; the forecaster's own chance of this, stated with the estimate: 85%; the middle value is on the limit's open side.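

In this assay, methyl in place of hydrogen on an amine nitrogen in a ring gives an at least 17-fold higher number from compound 3 to compound 4 (1.25 log units; beyond the scatter). Set beside the earlier step, the change carries over to the second core in direction, and its size on each core stays unresolved: the same change on two cores in this assay, an at least 110-fold higher number (2.07 log units; beyond the scatter) from compound 1 to compound 2 and an at least 17-fold higher number (1.25 log units; beyond the scatter) from compound 3 to compound 4; the limit leaves it open whether they differ Both methyl compounds end at a limit rather than a number, so the data show a large loss of potency on both cores but not its true size on either: the limit of > 10000 nM in this assay, at which 2 of the 4 values shown sit.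

Still open, from the compounds shown here alone, is whether ethyl or a longer chain on the same nitrogen behaves as methyl does. Also open, going by these compounds, is whether the step holds on a core bearing a nitrile.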